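The compounds below may be only part of what the source reports. "The series", "measured", "known", "first", "only" and "open" are said of these compounds alone.

In a functional assay on HUVEC cells (Homo sapiens) for inhibition, with a stated time of 4 days (a higher number here means a weaker inhibitor, a lower number a stronger inhibitor), three compounds have been measured so far. Compound 1 `COc1ccc(C(C)=O)cc1COc1ccc(Cl)cc1` gives 1200 nM. Compound 2 `COc1ccc(C(=O)O)cc1COc1ccc(Cl)c(C)c1` gives > 50000 nM, and this is a limit of the assay, not a number. Compound 3 `COc1ccc(C(N)=O)cc1/C=C/c1ccc(Cl)cc1` gives 87 nM, the lowest of the two true numbers, and its gap to compound 1, its nearest neighbour, lies beyond the usual scatter.

The next compound, compound 4 `COc1ccc(C(N)=O)cc1/C=C/c1ccc(C)cc1`, differs from compound 3 in one place: methyl in place of chloro on an aromatic carbon, para to a large group (methyl in place of chloro on an aromatic carbon). No measured pair among these compounds isolates this exchange, so the expectation rests on the value of compound 3, 87 nM, and on the small size of the change. In this assay, a modest move toward a higher number is expected, possibly no larger than the scatter. The expected size of the change is a 1.7-fold higher number from compound 3 to compound 4 (0.24 log units; within the scatter). Compound 4 is estimated at 150 nM, with an expected range of 40 nM to 600 nM.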

Compound 4, half-maximal inhibitory concentration: 1600 nM
Compound 4: the middle estimate sits 11-fold (1.03 log units) below what was measured; the whole stated range lies below it.
By their numbers in this assay, from the lowest: compound 3; then compounds 1 and 4 (each within the scatter of the next). At a limit, above all of these: compound 2.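

In this assay, the aromatic carbon para to a large group proves sensitive to this exchange: methyl in place of chloro gives an 18-fold higher number from compound 3 to compound 4 (1.26 log units; beyond the scatter). Among the compounds shown here, until now no two compounds differed in one place, so this is the first single change that can be read directly, and it is a large one. The two groups match in what can be counted, with one heavy atom each, no ring, no hydrogen-bond donors or acceptors and no net charge, and nothing measured here accounts for the size of the step.

As far as these compounds go, what a fluoro, bromo, trifluoromethyl or methoxy group would give at this position remains open. Also open, from the compounds shown here alone, is whether methyl in place of chloro would bring a step of similar size if a carboxylic acid stood in place of the amide on the shared core.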